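The compounds below may be only part of what the source reports. "The series", "measured", "known", "first", "only" and "open" are said of these compounds alone.

Measured so far:
compound 1 `CN1CCC(c2ccc3c(c2)oc(=O)n3C(=O)NCCCCc2ccccc2)CC1=O` gives 0.583 h
compound 2 `CC(C)CNC(=O)n1c(=O)oc2c(C3CCN(C)CC3)cccc21` gives 0.5 h
compound 3 `CC(C)CNC(=O)n1c(=O)oc2cc(C3CCCCN3C)ccc21` gives 0.25 h

All three values come from an ADME assay on microsomes from liver (Mus musculus) for metabolic stability, read by LC-MS, using NADPH, with stated times of 15 min and 60 min, tested at 4.6 uM (a higher number here means that the compound lasts longer, a lower number that the compound disappears faster), and no two of these compounds differ in one place only. Compound 1 (0.583 h) stands level with compound 2 (0.5 h) within the scatter, whereas compound 3 (0.25 h) lies lower, beyond the scatter.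

Compound 4 `CN1CCN(c2ccc3c(c2)oc(=O)n3C(=O)NCCCCc2ccccc2)CC1=O` has not yet been measured in this assay. It differs from compound 1 in a single group, with 4-methyl-3-oxopiperazin-1-yl in place of 1-methyl-2-oxopiperidin-4-yl on an aromatic carbon and the rest of the structure unchanged. For the measured compounds named here, no measured pair shows a swap of this kind, so the expectation rests on compound 1 at 0.583 h and on the structural change alone. The expected step of a 1.2-fold lower number from compound 1 to compound 4 (0.07 log units; within the scatter) is small and stays within the scatter, with a slight lean towards a lower number. Compound 4 is therefore estimated at 0.5 h, with 0.25 h to 1 h as its expected range.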

Compound 4, half-life: 0.5 h
Estimate against measurement, compound 4: no gap at the digits printed, and the stated range covers the measured number.
By their numbers in this assay, from the lowest: compounds 3, 2, 4 and 1 (each within the scatter of the next, the first and the last beyond it).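

Placing 4-methyl-3-oxopiperazin-1-yl in place of 1-methyl-2-oxopiperidin-4-yl on this aromatic carbon gives the first comparison in one place in this assay with a 1.2-fold lower number from compound 1 to compound 4 (0.07 log units; within the scatter) as its step. At this position, with the rest of the structure unchanged, a six-membered non-aromatic ring with 2 hetero atoms therefore stands level with one with 1 hetero atom, so the half-life does not separate the two groups. Nothing measured here accounts for this result.

As far as these compounds go, whether a morpholine ring or an open-chain amide on the same aromatic carbon would stand level with these two groups in this assay remains open. So does whether this swap would give a similar step with a chain other than the one shared by compound 1 and compound 4.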